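This account rests on a few compounds, and the source may have more. Where it says the series, first, only, none or still open, it means among the compounds named here.

The series is read in a functional assay on HL-60 cells (Homo sapiens) for inhibition (a lower number here means a stronger inhibitor, a higher number a weaker inhibitor), and so far it offers little to stand on. For compound 1 (`CC(C)CCCN(C)Cc1ccc(C2=CCCN(C)C2)cc1`) the entry is "not determined" (no result reported) and no number exists. Compound 3 (`CC(C)CN(C)Cc1ccc(C2CCCN(C)C2)cc1`) fares no better, with "not determined" (no result reported) as its entry, so it has no single number and cannot be placed on any scale. Only compound 2 (`CN1CCC=C(c2ccc(CN(C)Cc3ccc([N+](=O)[O-])cc3)cc2)C1`) gives a figure, with 2290 nM in this assay as the sole anchor for the set.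

The compound now awaiting measurement is compound 4 (`CN(Cc1ccc(Cl)cc1)Cc1ccc(C2CCCN(C)C2)cc1`) . The structural change is 4-chlorophenyl in place of isopropyl on a saturated chain carbon bound to an amine nitrogen and it amounts to 4-chlorophenyl in place of isopropyl on a saturated chain carbon bound to an amine nitrogen, which reads as isobutyl to 4-chlorobenzyl when cut one bond further out.

For the measured compounds named here, no measured step exists to size this change, and the missing number for compound 3 leaves no starting point. Going by the values given here, the only guide is compound 2 at 2290 nM in this series, and no departure beyond the usual scatter from that level, in either direction, is expected, though the uncertainty is wide. For compound 4 the estimated value is 2500 nM with an expected range from 600 nM to 10000 nM in this assay once it is measured.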

Compound 4, half-maximal inhibitory concentration: 1290 nM
Beside the measured number, compound 4's estimate is 1.9-fold (0.29 log units) above it; the range from low to high includes it.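

No step can be read from this result, since compound 3, the compound closest to compound 4, has no single number in this assay to compare with compound 4 at 1290 nM. No measured finding here explains the result. The compounds shown leave open how isobutyl and 4-chlorobenzyl compare in this series.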